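Moving a Chlorine on the Oxindole Part of Compound 1

The source may hold more compounds than are shown below. What is called first, only, known or untested is meant among the compounds shown, and "the series" means these compounds.

Compound 1, `COc1cc2c(/C=C3/C(=O)Nc4ccc(O)cc43)c(Cl)n(Cc3cc(OC)c(OC)c(OC)c3)c2cc1C`: 1410 nM
Compound 2, `COc1cc2c(/C=C3/C(=O)Nc4ccc(Cl)cc43)c(Cl)n(Cc3cc(OC)c(OC)c(OC)c3)c2cc1C`: 1860 nM

Both compounds were tested in a functional assay on cells (Leukemia cell, Homo sapiens) for cytotoxicity, with a stated time of 48 h; a lower number here means a stronger inhibitor of growth, a higher number a weaker inhibitor of growth. On these two numbers compound 1 has the lower one, yet its gap to compound 2 is a 1.3-fold higher number from compound 1 to compound 2 (0.12 log units; within the scatter), so the two are not told apart. Compound 3, `COc1cc2c(/C=C3/C(=O)Nc4cccc(Cl)c43)c(Cl)n(Cc3cc(OC)c(OC)c(OC)c3)c2cc1C`, has not yet been measured in this assay. Against compound 1 the change is a group of 12 heavy atoms (9 carbon, 1 nitrogen, 1 oxygen, 1 chlorine; one five-membered non-aromatic ring with 1 hetero atom, one six-membered aromatic ring of carbon only) in place of a group of 12 heavy atoms (9 carbon, 1 nitrogen, 2 oxygen; one five-membered non-aromatic ring with 1 hetero atom, one six-membered aromatic ring of carbon only), on an aromatic carbon, so the chloro now sits in a different spot of the same part of the molecule than in compound 2. Within the data shown here, the only step that bears on it is the one from compound 1 to compound 2, which was small. A step of about that size, if any, is therefore expected here too, in either direction or none at all. For compound 3 the expected value in this assay is 2000 nM, with a range from 800 nM to 5000 nM, which corresponds to an expected step of a 1.4-fold higher number from compound 1 to compound 3 (0.15 log units; within the scatter).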

Compound 3, concentration for 50% growth inhibition: 2450 nM
The estimate for compound 3 lay 1.2-fold (0.09 log units) below the measured number; low and high end bracket the measured number.
By their numbers in this assay, from the lowest: compounds 1, 2 and 3 (each within the scatter of the next).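

In this assay, moving the chloro to a different spot on the same part of the molecule gives a small step (a 1.3-fold higher number from compound 2 to compound 3 (0.12 log units; within the scatter)), and the comparison with the hydroxy-bearing compound is similar (a 1.7-fold higher number from compound 1 to compound 3 (0.24 log units; within the scatter)). The earlier pair showed only that chloro and hydroxy at one spot could not be told apart, whereas compound 3 shows that the spot of the chloro on this part does not separate these compounds in this assay either. Nothing measured here offers an explanation for these numbers.

Going by these compounds, it remains open whether a different group on this part, such as an amine or a carboxylic acid, would give a step beyond the scatter. On these data alone, it is also open how a hydroxy group would compare at the spot that carries the chloro in compound 3.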